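Amide nitrogen substituent changes on a shared diaryl aminothiophene core

The source may report more compounds than this note shows. Statements on the series, on what has been measured and on what is new or still open speak of the compounds shown alone.

Measured compounds in a functional assay on PC-3 cells (Homo sapiens) for inhibition, read by sulforhodamine B assay, with a stated time of 72 h; on this read-out higher numbers stand for weaker inhibition and lower numbers for stronger inhibition:
compound 1, `CC(C)(C)NC(=O)c1c(N)sc(-c2ccc(Cl)cc2)c1-c1ccc(Cl)cc1`, gives 15100 nM
compound 2, `COc1ccc(CNC(=O)c2c(N)sc(-c3ccc(Cl)cc3)c2-c2ccc(Cl)cc2)cc1`, gives 29500 nM
compound 3, `Nc1sc(-c2ccc(Cl)cc2)c(-c2ccc(Cl)cc2)c1C(=O)NC1CC1`, gives 3680 nM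

Compound 1 stands second highest of the three numbers: compound 2 lies within the scatter of it, a 2.0-fold higher number from compound 1 to compound 2 (0.29 log units; within the scatter), while compound 3 lies beyond it, a 4.1-fold lower number from compound 1 to compound 3 (0.61 log units; beyond the scatter). Compound 4, `CC1CCN(C(=O)c2c(N)sc(-c3ccc(Cl)cc3)c2-c2ccc(Cl)cc2)CC1`, is not yet measured in this assay. It differs from compound 1 thus: 4-methylpiperidin-1-yl in place of (tert-butyl)amino on a carbonyl carbon. For the measured compounds named here, both measured steps only swap the group on the amide-type nitrogen and keep its hydrogen; compound 4 instead loses that hydrogen-bond donor and gains a six-membered non-aromatic ring, a change no measured step covers. Only the small cyclopropyl gave a lower number; a bulkier group gave none beyond the scatter. A number near compound 1, or somewhat higher, is therefore expected, a 1.5-fold higher number from compound 1 to compound 4 (0.16 log units; within the scatter). For compound 4 the estimate is 22000 nM, range 7000 nM to 70000 nM.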

Compound 4, half-maximal inhibitory concentration: 5750 nM
Estimate against measurement, compound 4: 3.8-fold (0.58 log units) above; measured number outside the range, below it.
By their numbers in this assay, from the lowest: compounds 3 and 4 (each within the scatter of the next); then compounds 1 and 2 (each within the scatter of the next).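

In this assay the amide hydrogen proves dispensable on this carbonyl carbon: 4-methylpiperidin-1-yl gives a 2.6-fold lower number from compound 1 to compound 4 (0.42 log units; beyond the scatter) and a 5.1-fold lower number from compound 2 to compound 4 (0.71 log units; beyond the scatter), while a 1.6-fold higher number from compound 3 to compound 4 (0.19 log units; within the scatter) leaves those two within the scatter of each other. Low numbers are therefore not confined to the cyclopropyl of compound 3, and the larger ring-bearing group of compound 4 does not raise the number. No evidence on the origin of this shift is available.

Still open, on these data alone, is what the 4-methyl group contributes, since piperidin-1-yl itself is absent from this set. Morpholin-4-yl and dimethylamino at this place also remain open.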